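The source may hold more compounds than are shown below. What is called first, only, known or untested is meant among the compounds shown, and "the series" means these compounds.

Compound 1 `CCCCC#Cc1ccc(S(=O)(=O)Nc2cccc(-c3csc(NC(C)=O)n3)c2)cc1` — in a functional assay on A-375 cells (Homo sapiens) for antiproliferative activity, read by trypan blue exclusion, with a stated time of 48 h, tested at 10 uM (on this read-out lower numbers stand for a stronger effect and higher numbers for a weaker effect at the one concentration tested), it is reported as < 1%.
Compound 2 `CC(=O)Nc1nc(-c2cccc(NS(=O)(=O)c3ccc(C#CCO)cc3)c2)cs1` — in this assay compound 2 gives 48.8%.

The value of compound 1 is a limit of this assay, not a number. Among the compounds with values here, compound 2 therefore holds the only number among the two values shown, while the other value sits at a limit, as the limit of < 1% in this assay, at which 1 of the 2 values shown sits, records. Within the data shown here, only one measured step exists, a number at least 47.8 percentage points higher from compound 1 to compound 2 (beyond the scatter), and it is large. Compound 3 `CC(=O)Nc1nc(-c2cccc(NS(=O)(=O)c3ccc(C#CC4CCCCC4)cc3)c2)cs1` differs from compound 2 by cyclohexyl in place of hydroxymethyl on a triple-bonded carbon. Among the measured compounds shown here, this change runs in the opposite sense to the one measured step: the hydroxy-bearing group leaves and a carbon ring enters on the triple-bonded carbon. On that basis compound 3 is expected to show a large fall in this assay, a number 40.8 percentage points lower from compound 2 to compound 3 (beyond the scatter), with a fair chance that only a limit is reported. The estimate for compound 3 is 8%, within a range from 1% to 30%.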

Compound 3, a percentage reported as activity, at one concentration (the size of the read-out at that concentration, not a potency): 1.2%
The estimate for compound 3 lay 6.8 percentage points above the measured number; the range from low to high includes it.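

In this assay, the change on the triple-bonded carbon gives a number 47.6 percentage points lower from compound 2 to compound 3 (beyond the scatter), so the low read-out is not confined to the open butyl chain of compound 1 but also appears with a six-membered carbon ring, and of the three compounds only compound 2, with its hydroxymethyl, stands clearly apart. Exchanging butyl for cyclohexyl gives a number at least 0.2 percentage points higher from compound 1 to compound 3 (that floor lies within the scatter), so the two carbon groups cannot be told apart here. The value of compound 1 is a limit and not a number: the limit of < 1% in this assay, at which 1 of the 3 values shown sits.

The compounds shown leave open whether the hydroxy group itself sets the weaker effect of compound 2 or whether any short chain would do the same. An aminomethyl group, a carboxylic acid or a longer chain ending in hydroxy on the triple-bonded carbon would help to separate these readings.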